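The source may hold more compounds than are shown below. What is called first, only, known or untested is meant among the compounds shown, and "the series" means these compounds.

Within the data shown here, in a functional assay on Hs-578T cells (Homo sapiens) for antiproliferative activity (on this read-out higher numbers stand for weaker inhibition of growth and lower numbers for stronger inhibition of growth), compound 1 (`COCCCCCCCCCCC/C=C1\CC(CO)(COC(=O)C(C)(C)C)OC1=O`) gives 7.34 ug/mL and compound 2 (`CCCCCOCCCCCCC/C=C1\CC(CO)(COC(=O)C(C)(C)C)OC1=O`) gives 3 ug/mL, the lower of the two numbers so far. Compound 3 (`CC(C)(C)C(=O)OCC1(CO)C/C(=C\CCCCCCCCCCCCCCC=O)C(=O)O1`) is not yet measured, and its difference from compound 2 is 7-formylheptyl in place of pentyloxy on a saturated chain carbon, seven bonds along the chain from a double-bonded chain carbon. Among the measured compounds shown here, only one measured step bears on this change: a 2.4-fold lower number from compound 1 to compound 2 (0.39 log units; beyond the scatter), a modest step that puts pentyloxy in place of 4-methoxybutyl at the same place on the chain. For the measured compounds named here, no measured compound carries a formyl group, so the data give no firm direction, and a single step is a thin guide to size. In this assay the expected change is therefore small, with an estimated step of a 1.3-fold higher number from compound 2 to compound 3 (0.12 log units; within the scatter) and no shift beyond the scatter expected. For compound 3 the estimated value is 4 ug/mL, with an expected range from 1.4 ug/mL to 11 ug/mL.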

Compound 3, concentration for 50% growth inhibition: > 10 ug/mL
Compound 3 was reported as a limit; the forecaster's own chance of this, stated with the estimate: 3%; at least 2.5-fold (0.39 log units) between middle value and limit.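

In this assay compound 3 is reported only as a limit and not as a number: the limit of > 10 ug/mL in this assay, at which 1 of the 3 values shown sits. Among these compounds, replacing pentyloxy with 7-formylheptyl at this place on the chain gives an at least 3.3-fold higher number from compound 2 to compound 3 (0.52 log units; beyond the scatter) and is the first step towards weaker inhibition of growth, so this place does not tolerate every group equally. The comparison with the other measured compound is less telling, since an at least 1.3-fold higher number from compound 1 to compound 3 (0.13 log units; that floor lies within the scatter) gives only a floor and does not separate those two compounds.

As far as these compounds go, how far compound 3 lies past its limit stays open, and so does whether the formyl group or the added chain length accounts for the step. Also open, from the compounds shown here alone, is whether a plain alkyl chain of the same length, or a carboxylic acid or hydroxyl at the chain end, would behave like the formyl group.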